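The source may hold more compounds than are shown below. What is called first, only, known or untested is meant among the compounds shown, and "the series" means these compounds.

Measured so far in a functional assay on PC-3 cells (Homo sapiens) for antiproliferative activity, read by MTT assay, with a stated time of 48 h; a higher number here means a weaker inhibitor, a lower number a stronger inhibitor:

- Compound 1 `COc1ccc(CN(C(=O)CSc2nc3ccccc3s2)c2cc(OC)c(OC)c(OC)c2)cc1OC`: > 80000 nM, a limit of the assay and not a number
- Compound 2 `COc1cc(N(Cc2ccc(Cl)cc2)C(=O)CSc2nc3ccccc3s2)cc(OC)c1OC`: > 80000 nM, a limit of the assay and not a number
- Compound 3 `COc1ccc(CN(C(=O)CSc2nc3ccccc3s2)c2cc(OC)c(OC)c(OC)c2)cc1F`: 20100 nM

Compound 3 is the only one of the three with a true number, and at 20100 nM it is the most potent of them. Compound 4 `COc1ccc(CN(C(=O)CSc2nc3ccccc3s2)c2cc(OC)c(OC)c(OC)c2)cc1Br` alters a single group of compound 3: bromo in place of fluoro on an aromatic carbon. The 3-fluoro-4-methoxybenzyl group thus becomes 3-bromo-4-methoxybenzyl.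

For the measured compounds named here, two measured steps bear on this. Fluoro in place of methoxy, on the aromatic carbon that changes here, gave an at least 3.9-fold lower number from compound 1 to compound 3 (0.59 log units; beyond the scatter). Putting 3-fluoro-4-methoxyphenyl in place of 4-chlorophenyl gave an at least 3.9-fold lower number from compound 2 to compound 3 (0.59 log units; beyond the scatter). Neither step replaces the fluoro itself, and both sizes start from a limit, so they say little about bromo.

Bromo keeps a halogen on that carbon, as compound 3 does at 20100 nM, so no change beyond the scatter is expected. The estimate is a 1.1-fold lower number from compound 3 to compound 4 (0.05 log units; within the scatter). Compound 4 is estimated at 18000 nM, with an expected range of 6000 nM to 60000 nM.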

Compound 4, half-maximal inhibitory concentration: 16000 nM
For compound 4 the middle estimate is 1.1-fold (0.05 log units) above the measured one; low and high end bracket the measured number.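

In this assay, for the compounds shown here, the first direct swap of one halogen for another on this carbon gives a 1.3-fold lower number from compound 3 to compound 4 (0.10 log units; within the scatter), so fluoro and bromo cannot be told apart here. Bromo in place of methoxy gives an at least 5.0-fold lower number from compound 1 to compound 4 (0.69 log units; beyond the scatter), and 3-bromo-4-methoxyphenyl in place of 4-chlorophenyl gives an at least 5.0-fold lower number from compound 2 to compound 4 (0.69 log units; beyond the scatter), so the gain seen with fluoro is not unique to fluoro. Both sizes are only minimums, because compound 1 and compound 2 each sit at a limit of the assay and not a number: the limit of > 80000 nM in this assay, at which 2 of the 4 values shown sit.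

The compounds shown leave open whether a halogen is needed on this carbon, or whether a hydroxyl, an amine or a nitrile there would serve as well. They also leave open whether any group at this position can give a much lower number than compound 4, at 16000 nM.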